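A few compounds are considered here, and "the series" means these few. Any claim that something is new, unique, unknown or untested is made for them only; others in the source may bear on it.

Compound 1 `Oc1ccccc1-c1cc(-c2ccccc2F)cc(-c2ccccc2O)n1` carries a fluoro group on one outer ring. In a functional assay on HCT-15 cells (Homo sapiens) for inhibition (on this read-out lower numbers stand for stronger inhibition and higher numbers for weaker inhibition), compound 1 gives only the assay limit > 50000 nM. Compound 2 `Oc1ccccc1-c1cc(-c2ccccc2C(F)(F)F)cc(-c2ccccc2O)n1` puts trifluoromethyl at that place, and in this assay compound 2 gives 3970 nM; the step of an at least 12-fold lower number from compound 1 to compound 2 (1.10 log units; beyond the scatter) is large. Compound 2 thus holds the only number shown, since the limit of > 50000 nM in this assay, at which 1 of the 2 values shown sits, covers the other value. Compound 3 `Oc1ccccc1-c1cc(-c2ccccc2OC(F)(F)F)cc(-c2ccccc2O)n1` differs by trifluoromethoxy in place of trifluoromethyl on an aromatic carbon. Among the measured compounds shown here, no measured step probes this exchange; the one step known concerns the fluoro-to-trifluoromethyl change. With groups of similar size, compound 3 is expected near compound 2, with an estimated step of a 1.0-fold higher number from compound 2 to compound 3 (0.00 log units; within the scatter) within scatter. For compound 3 in this assay the estimate is 4000 nM, range 1500 nM to 12000 nM.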

Compound 3, half-maximal inhibitory concentration: 4520 nM
The estimate for compound 3 lay 1.1-fold (0.05 log units) below the measured number; the measured number falls inside the stated range.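

Trifluoromethoxy and trifluoromethyl on this aromatic carbon cannot be told apart in this assay, with a 1.1-fold higher number from compound 2 to compound 3 (0.06 log units; within the scatter). Against fluoro, a second group now gives a large step, an at least 11-fold lower number from compound 1 to compound 3 (1.04 log units; beyond the scatter), so the large step seen with trifluoromethyl is not confined to that one group. That step is a bound, not an exact size, as it starts from a limit: the limit of > 50000 nM in this assay, at which 1 of the 3 values shown sits.

Open, as far as these compounds go, is whether a methyl, a methoxy or an amine at this place would match compound 2 and compound 3, and so what these two groups share that matters here.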